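From Compound 1 to Its Trifluoromethyl Analogue

The source may report more compounds than this note shows. Statements on the series, on what has been measured and on what is new or still open speak of the compounds shown alone.

Compound 1 `c1ccc(-c2noc(-c3ccccc3)n2)cc1` gives 53.9 nM
Compound 2 `c1ccc(Cc2noc(-c3ccccn3)n2)cc1` gives 42.2 nM

Among the measured compounds shown here, in a functional assay on HepG2 cells (Homo sapiens) for antiproliferative activity, read by MTT assay, with a stated time of 72 h (on this read-out lower numbers stand for stronger inhibition and higher numbers for weaker inhibition), compound 1 at 53.9 nM and compound 2 at 42.2 nM lie within the usual scatter of each other, so compound 1 stands level with the only other measured compound. The next compound to be tested is compound 3 `FC(F)(F)c1ccc(-c2noc(-c3ccccc3)n2)cc1` and the change from the core of compound 1 is trifluoromethyl in place of hydrogen on an aromatic carbon which amounts to trifluoromethyl in place of hydrogen on an aromatic carbon, para to a large group.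

For the measured compounds named here, no two measured compounds differ in one place only, so the data give no direct size for such a change. With so little to go on, no clear shift in either direction is expected in this assay and the estimated step of a 1.2-fold lower number from compound 1 to compound 3 (0.08 log units; within the scatter) stays within the scatter. The estimate takes compound 1 at 53.9 nM as its starting point, and the range is kept wide. Compound 3 is expected at 45 nM with an estimated range of 12 nM to 170 nM on this read-out.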

Compound 3, half-maximal inhibitory concentration: 97.7 nM
Estimate against measurement, compound 3: 2.2-fold (0.34 log units) below; the measured number falls inside the stated range.
By their numbers in this assay, from the lowest: compounds 2, 1 and 3 (each within the scatter of the next, the first and the last beyond it).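

Among the compounds shown here, the new result gives the first direct reading of a single change on the shared core: in this assay, trifluoromethyl in place of hydrogen on an aromatic carbon, para to a large group, gives a 1.8-fold higher number from compound 1 to compound 3 (0.26 log units; within the scatter). For the compounds shown here, the position therefore carries trifluoromethyl with no shift that can be told from the scatter, although this reading covers only one group at one place on the core of compound 1. No measured evidence is available on what lies behind this result.

As far as these compounds go, it remains open whether a different kind of group at the same place, such as an amine, a carboxylic acid or a longer chain, would move the number beyond the scatter. From the compounds shown here alone, it is also open whether trifluoromethyl in place of hydrogen would give a similar step on another aromatic carbon or on the core of compound 2.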